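Amino Substitution on a Thiophene Nucleoside Core

The compounds below may be only part of what the source reports. "The series", "measured", "known", "first", "only" and "open" are said of these compounds alone.

Measured so far:
Compound 1 `COc1ncnc2c1c(-c1ccsc1)cn2[C@@H]1O[C@H](CO)[C@@H](O)[C@H]1O` gives 3350 nM in a functional assay on HeLa S3 cells (Homo sapiens) for antiproliferative activity, read by XTT assay, with a stated time of 72 h; a higher number here means a weaker inhibitor, a lower number a stronger inhibitor.
Compound 2 `COc1nc(N)nc2c1c(-c1ccsc1)cn2[C@@H]1O[C@H](CO)[C@@H](O)[C@H]1O` reaches only the limit > 20000 nM in this assay.
Compound 3 `COc1ncnc2c1c(-c1cccs1)cn2[C@@H]1O[C@H](CO)[C@@H](O)[C@H]1O` gives 1760 nM in this assay.

The value for compound 2 is a limit of the assay and not a number, a point made plain by the limit of > 20000 nM in this assay, at which 1 of the 3 values shown sits. Compound 2 differs from compound 1 by amino in place of hydrogen on an aromatic carbon, and this change produced an at least 5.9-fold higher number from compound 1 to compound 2 (0.77 log units; beyond the scatter). Compound 3 differs from compound 1 in its core by thiophen-2-yl in place of thiophen-3-yl on an aromatic carbon, which gave a 1.9-fold lower number from compound 1 to compound 3 (0.28 log units; within the scatter), a gap that stays within the usual scatter, so the two cores cannot be ranked against each other.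

Compound 4 `COc1nc(N)nc2c1c(-c1cccs1)cn2[C@@H]1O[C@H](CO)[C@@H](O)[C@H]1O` has not yet been measured. It differs from compound 3 by amino in place of hydrogen on an aromatic carbon. The place of this change reads the same, word for word, as in the change from compound 1 to compound 2, so it is the same change made on the other core.

Because the earlier step of an at least 5.9-fold higher number from compound 1 to compound 2 (0.77 log units; beyond the scatter) was at least modest and ended at the assay limit, compound 4 is expected to show a similarly sized step, an 8.5-fold higher number from compound 3 to compound 4 (0.93 log units; beyond the scatter). Compound 4 is therefore estimated at 15000 nM in this assay, in a range from 6000 nM to 40000 nM, with a real chance that only a limit is reported.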

Compound 4, half-maximal inhibitory concentration: > 20000 nM
Compound 4 ended at the assay's limit; the forecaster's own chance of this, stated with the estimate: 55%; middle value at least 1.3-fold (0.12 log units) away from the limit.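

Placing an amino group on the aromatic carbon between the two ring nitrogen atoms gave an at least 11-fold higher number from compound 3 to compound 4 (1.05 log units; beyond the scatter) in this assay, so the weakening seen on the core of compound 1 appears again on the core of compound 3. In these two pairs the change therefore carries over from one core to the other in its direction, and in both it lies beyond the scatter: the same change on two cores in this assay, an at least 5.9-fold higher number (0.77 log units; beyond the scatter) from compound 1 to compound 2 and an at least 11-fold higher number (1.05 log units; beyond the scatter) from compound 3 to compound 4; the limit leaves it open whether they differ What this does not show is the true size of the change on either core, and the step between the two amino compounds, compound 2 and compound 4, cannot be read, as each ends at a limit of the assay and not at a number: the limit of > 20000 nM in this assay, at which 2 of the 4 values shown sit.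

The compounds shown cover only two closely related cores, which differ solely in how the thiophene is attached, so it stays open whether the amino group would have the same effect on a core with another ring in that place, such as phenyl. As far as these compounds go, it is also open whether the weakening belongs to the amino group itself or would follow other groups on that same carbon, such as a methyl group or a methylamino group.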